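A few compounds are considered here, and "the series" means these few. Any claim that something is new, unique, unknown or untested is made for them only; others in the source may bear on it.

Compound 2 `COc1cc(NC(=O)Nc2cc(Nc3cccc(C(C)(C)C)c3)ncn2)cc(OC)c1` gives 13.1% in a functional assay on NCI-H520 cells (Homo sapiens) for inhibition, read by MTT assay, with a stated time of 48 h, tested at 10 uM (on this read-out lower numbers stand for less inhibition and higher numbers for more inhibition at the one concentration tested (going by the name of the read-out)), the lowest of the three measured numbers; compound 3 `CC(C)(C)c1cccc(Nc2cc(NC(=O)Nc3c(Cl)cccc3Cl)ncn2)c1` gives 29.6% and compound 1 `COc1ccc(OC)c(Nc2cc(NC(=O)Nc3c(Cl)cccc3Cl)ncn2)c1` gives 74%. For the measured compounds named here, the only measured single-point step, a number 16.5 percentage points higher from compound 2 to compound 3 (beyond the scatter), concerns the amide-type nitrogen and so does not directly bear on the present change. Compound 4 `COc1cc(NC(=O)Nc2cc(Nc3cc(I)ccc3OC)ncn2)cc(OC)c1` differs from compound 2 by 5-iodo-2-methoxyphenyl in place of 3-(tert-butyl)phenyl on a nitrogen on an aromatic ring. Compounds 1 and 3 share the rest of their structure and differ only at that same nitrogen, and there the number of compound 1 lies far above that of compound 3, so an increase on this read-out is expected for compound 4, though with wide uncertainty. Compound 4 is therefore estimated at 38% (range 12% to 68%), an expected step of a number 24.9 percentage points higher from compound 2 to compound 4 (beyond the scatter).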

Compound 4, a percentage reported as inhibition, at one concentration (the size of the read-out at that concentration, not a potency): 55%
The estimate for compound 4 lay 17 percentage points below the measured number, and the stated range covers the measured number.
By their numbers in this assay, from the lowest: compound 2; then compound 3; then compound 4; then compound 1.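

In this assay, a number 41.9 percentage points higher from compound 2 to compound 4 (beyond the scatter), the only step shown at this nitrogen on an aromatic ring. It shows that, with the rest of compound 2 held fixed, the group at this position alone can shift the read-out substantially. Nothing shown here explains that shift. The iodine and the methoxy group enter together, leaving their separate contributions open. Also open, from the compounds shown here alone, is how the read-out would respond if an amine or a carboxylic acid stood in place of the iodine.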